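The source may hold more compounds than are shown below. What is called first, only, known or untested is meant among the compounds shown, and "the series" means these compounds.

Working notes on the series, read in an ADME assay on CHO cells (Cricetulus griseus) for inhibition, read by MTT assay; on this read-out higher numbers stand for weaker inhibition and lower numbers for stronger inhibition. Compound 1 (`CCN(CC)Cc1cc(Nc2nc3ccccc3n2Cc2ccc(C(F)(F)F)cc2)ccc1O`) gives 17500 nM. Compound 2 (`CCN(CC)Cc1cc(C)cc(Nc2nc3ccccc3n2Cc2ccc(C#N)cc2)c1O`) gives 14200 nM, within the scatter of compound 1. Compound 3 (`CCN(CC)Cc1cc(F)cc(Nc2nc3ccccc3n2Cc2ccc(C(F)(F)F)cc2)c1O`) gives > 50000 nM, which is a limit of the assay and not a number. Within the data shown here, compound 1 therefore stands level with compound 2 on the only two numeric values available, while the third result is a limit.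

The step of interest leads to compound 4 (`CCN(CC)Cc1cc(Nc2nc3ccccc3[nH]2)ccc1O`): hydrogen in place of 4-(trifluoromethyl)benzyl on an aromatic nitrogen. In words, hydrogen stands in place of 4-(trifluoromethyl)benzyl on an aromatic nitrogen. Among the measured compounds shown here, no measured pair isolates this change, and no measured compound lacks a group on that nitrogen, so the expectation is weakly anchored. The starting point is compound 1, which gives 17500 nM. A moderate move in this assay towards a higher number, meaning weaker inhibition, is expected, and a result reported only as a limit is possible. The expected step is a 2.0-fold higher number from compound 1 to compound 4 (0.30 log units; within the scatter). For compound 4 the estimated value is 35000 nM, with an expected range of 12000 nM to 90000 nM.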

Compound 4, half-maximal inhibitory concentration: > 50000 nM
Compound 4: only a limit was reported; the forecaster's own chance of this, stated with the estimate: 40%; at least 1.4-fold (0.15 log units) between middle value and limit.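

In this assay, among these compounds, hydrogen in place of 4-(trifluoromethyl)benzyl on the aromatic nitrogen gives the first direct reading at this position, and it goes towards weaker inhibition: an at least 2.8-fold higher number from compound 1 to compound 4 (0.45 log units; beyond the scatter). Compound 4 gives > 50000 nM, which is a limit of the assay and not a number. The full size of the step cannot be read, because the result sits at the limit: the limit of > 50000 nM in this assay, at which 2 of the 4 values shown sit.

This single pair does not show whether the difference follows the benzyl ring or its trifluoromethyl group, a question that a plain benzyl, a methyl or a longer chain on that nitrogen would address. Compound 2 and compound 3 each differ from compound 1 in more than one place, so neither separates the effect of this change.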